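Aryl Swap on the Ring Amine Nitrogen of Compound 1

The source may hold more compounds than are shown below. What is called first, only, known or untested is meant among the compounds shown, and "the series" means these compounds.

Three compounds have been measured in an assay on HEK293 cells for inhibition of Voltage-dependent T-type calcium channel subunit alpha-1G (Homo sapiens), read by fluorescence, tested at 10 uM; on this read-out higher numbers stand for more inhibition at the one concentration tested (going by the name of the read-out) and lower numbers for less inhibition:
Compound 1 `CCCc1nc(-c2ccccc2)c(CNCCCN2CCN(c3cccc(C)c3C)CC2)o1` gives 55.2%
Compound 2 `CCCc1nc(-c2ccccc2)c(CNCCN2CCN(c3cccc(C)c3C)CC2)o1` gives 66.7%
Compound 3 `CCCc1nc(-c2ccccc2)c(CNCCN2CCN(c3ccccc3)CC2)o1` gives 54.3%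

Compound 1 stands second highest of the three in this assay. Its nearest neighbour is compound 3, whose value sits within the scatter of that of compound 1; compound 2 lies furthest away, with a value beyond the scatter above that of compound 1.

The step to the unmeasured compound 4 `CCCc1nc(-c2ccccc2)c(CNCCCN2CCN(c3ccc(Cl)cc3)CC2)o1` is 4-chlorophenyl in place of 2,3-dimethylphenyl on an amine nitrogen in a ring. Going by the values given here, one measured step bears on this change: a number 12.4 percentage points lower from compound 2 to compound 3 (beyond the scatter). There the 2,3-dimethylphenyl group was replaced by a plain phenyl, and the number fell by a modest amount. Among the compounds with values here, compound 4 carries a 4-chlorophenyl rather than a plain phenyl, and no measured pair shows what a 4-chlorophenyl does, so the comparison is only partial.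

On this basis a modest fall in this assay is expected, of about a number 9.2 percentage points lower from compound 1 to compound 4 (within the scatter), because a number 12.4 percentage points lower from compound 2 to compound 3 (beyond the scatter) shows that the number fell when the 2,3-dimethylphenyl was lost. Compound 4 is therefore estimated at 46%, with a range from 30% to 64%.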

Compound 4, a percentage reported as inhibition, at one concentration (the size of the read-out at that concentration, not a potency): 63.3%
Compound 4: the middle estimate sits 17.3 percentage points below what was measured, within the range that was stated.
By their numbers in this assay, from the lowest: compounds 3, 1, 4 and 2 (each within the scatter of the next, the first and the last beyond it).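

In this assay, 4-chlorophenyl in place of 2,3-dimethylphenyl on the amine nitrogen in a ring gives a number 8.1 percentage points higher from compound 1 to compound 4 (within the scatter), so on the core of compound 1 this exchange of aryl groups leaves the read-out within the scatter. Going by these compounds alone, this is the first look at a 4-chlorophenyl at this position, and it shows that giving up the 2,3-dimethylphenyl need not cost activity beyond the scatter, whereas the only earlier step at this position, a number 12.4 percentage points lower from compound 2 to compound 3 (beyond the scatter), did go beyond it. That earlier step differs from the new one in both the entering group and the core, and nothing available explains the contrast between them.

The compounds shown leave open what a plain phenyl would give on the core of compound 1 and what a 4-chlorophenyl would give on the core of compound 2, so the contributions of the aryl group and the core cannot yet be separated. They also leave open how other groups on this nitrogen, such as a 4-fluorophenyl or a 4-methoxyphenyl, would read in this assay on either core.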